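Bromophenyl Variant Tested Against an Assay Limit

The compounds below may be only part of what the source reports. "The series", "measured", "known", "first", "only" and "open" are said of these compounds alone.

Three compounds built on one shared core have been examined in an ADME assay on A549 cells (Homo sapiens) for cytotoxicity, read by MTT assay, with a stated time of 48 h; on this read-out lower numbers stand for stronger inhibition of growth and higher numbers for weaker inhibition of growth. Compound 1 `O=C(/C=C\c1cccc([N+](=O)[O-])c1)N1N=C(c2ccncc2)OC1c1c[nH]c2ccccc12` gives in this assay only a limit, > 30 ug/mL. Compound 2 `O=C(/C=C\c1ccccc1F)N1N=C(c2ccncc2)OC1c1c[nH]c2ccccc12` likewise gives in this assay only a limit, > 30 ug/mL. Compound 3 `O=C(/C=C\c1ccc(Cl)cc1)N1N=C(c2ccncc2)OC1c1c[nH]c2ccccc12` gives in this assay only a limit as well, > 30 ug/mL. For the measured compounds named here, because of the limit of > 30 ug/mL in this assay, at which 3 of the 3 values shown sit, no step among the three can be read, and compound 2 stands at that limit with no number of its own.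

Compound 4 `O=C(/C=C\c1cccc(Br)c1)N1N=C(c2ccncc2)OC1c1c[nH]c2ccccc12` is the unmeasured member. It differs from compound 2 in one place: 3-bromophenyl in place of 2-fluorophenyl on a double-bonded chain carbon bound to a double-bonded chain carbon. The measured steps that bear on this change, a step that the two limits leave unreadable from compound 1 to compound 2 and a step that the two limits leave unreadable from compound 2 to compound 3, alter the same position, but both are of unreadable size, so no direction can be drawn from them. With every measured value sitting at the limit, compound 4 is expected to do the same, and its estimated result in this assay is 40 ug/mL, ranging from 15 ug/mL to 100 ug/mL. The expected step from compound 2 to compound 4 is a step that the limit leaves unreadable from compound 2 to compound 4, which in practice means no readable change.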

Compound 4, concentration for 50% growth inhibition: > 30 ug/mL
Compound 4: no number, only a limit; the forecaster's own chance of this, stated with the estimate: 80%; the middle value does not contradict the limit.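

For the compounds shown here, compound 4 also gives only a limit in this assay, so no step from compound 1, compound 2 or compound 3 to compound 4 can be read, because all four compounds sit at the same limit: the limit of > 30 ug/mL in this assay, at which 4 of the 4 values shown sit.

The compounds shown leave open how far these four compounds differ from one another, and whether any substituted phenyl at this place gives a measurable value.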